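Removing one methoxy group from compound 2

A few compounds are considered here, and "the series" means these few. Any claim that something is new, unique, unknown or untested is made for them only; others in the source may bear on it.

Compound 1 `COC(=O)Nc1sc2c(c1C(=O)Nc1ccc(OC)cc1)CCCCC2` gives > 50000 nM in an ADME assay on THP-1 cells (Homo sapiens) for cytotoxicity; a higher number here means that more compound is tolerated, a lower number that less compound is tolerated
Compound 2 `COc1cccc(NC(=O)c2c(NC(=O)C(F)(F)F)sc3c2CCCCC3)c1` gives 37600 nM in this assay

Compound 1 sits at > 50000 nM as a limit of the assay and not a number. For the measured compounds named here, compound 2 at 37600 nM holds the only true number here, so it is the one firm starting point. Compound 3 `O=C(Nc1ccccc1)c1c(NC(=O)C(F)(F)F)sc2c1CCCCC2` is compound 2 with a single change (hydrogen in place of methoxy on an aromatic carbon), hydrogen in place of methoxy on an aromatic carbon, so 3-methoxyphenyl becomes phenyl. Going by the values given here, no measured pair shows this change, so no step beyond the usual scatter is expected in this assay here. The estimate means a 1.1-fold higher number from compound 2 to compound 3 (0.03 log units; within the scatter) as the expected step. Compound 3 is expected near 40000 nM (estimated range 18000 nM to 75000 nM).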

Compound 3, half-maximal cytotoxic concentration: > 50000 nM
Compound 3 ended at the assay's limit; the forecaster's own chance of this, stated with the estimate: 35%; middle value at least 1.2-fold (0.09 log units) from the limit.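

Replacing methoxy with hydrogen on this aromatic carbon, so that 3-methoxyphenyl becomes phenyl, gives an at least 1.3-fold higher number from compound 2 to compound 3 (0.12 log units; that floor lies within the scatter) in this assay. This first measured pair shows that the cells still tolerate the compound at high concentration without the methoxy group. The value of compound 3 is a limit and not a number, so the full size of this step cannot be read: the limit of > 50000 nM in this assay, at which 2 of the 3 values shown sit.

As far as these compounds go, it remains open whether an amine or a carboxylic acid on this same carbon would bring a true number in this assay, and whether that number would differ from compound 2 by more than the scatter.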